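A few compounds are considered here, and "the series" means these few. Any claim that something is new, unique, unknown or untested is made for them only; others in the source may bear on it.

Working notes on the series. Compound 3 `CCC1(CCCCN2CCN(c3ccc(Cl)cc3)CC2)C(=O)Nc2ccccc21` is the reference point for this step. In a functional assay on the whole organism (strain NMRI) with Mus musculus as the target, with stated times of 30 min and 5 min (a higher number here means that more compound is needed for the effect, a lower number that less compound is needed), compound 3 gives only a limit of the assay, > 10 mg/kg. Compound 1 `CCC1(CCCCN2CCN(c3ccc(Cl)cc3)CC2)C(=O)Nc2cc(F)ccc21` likewise gives a limit in this assay, > 10 mg/kg. Compound 2 `CCC1(CCCCN2CCN(c3cccc(Cl)c3)CC2)C(=O)Nc2ccccc21` gives a limit as well, > 20 mg/kg. The steps a step that the two limits leave unreadable from compound 1 to compound 3 and a step that the two limits leave unreadable from compound 2 to compound 3 therefore cannot be sized; compound 3 sits at the limit of > 10 mg/kg in this assay, at which 2 of the 3 values shown sit, while compound 2 sits at the limit of > 20 mg/kg in this assay, at which 1 of the 3 values shown sits. The change to compound 4 `CCC1(CCCCN2CCN(c3ccc(F)cc3)CC2)C(=O)Nc2ccccc21` is fluoro in place of chloro on an aromatic carbon. Going by the values given here, no measured step bears on this change, and the two steps that exist are unreadable, so no step beyond the scatter is expected. Compound 4 is expected at 30 mg/kg, between 10 mg/kg and 100 mg/kg. The expected step is a step that the limit leaves unreadable from compound 3 to compound 4.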

Compound 4, minimum effective dose: < 1 mg/kg
Compound 4 ended at the assay's limit; the forecaster's own chance of this, stated with the estimate: 80%; middle value at least 30-fold (1.47 log units) from the limit.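

In this assay, going by these compounds alone, 4-fluorophenyl in place of 4-chlorophenyl gives the first change whose size can be read: an at least 10-fold lower number from compound 3 to compound 4 (1.00 log units; beyond the scatter). The step with 4-fluorophenyl in place of 3-chlorophenyl is also readable: an at least 20-fold lower number from compound 2 to compound 4 (1.30 log units; beyond the scatter). Compound 4 gives < 1 mg/kg, which is a limit, so both steps are minimum sizes, and it stands alone at this end of the series: the limit of < 1 mg/kg in this assay, at which 1 of the 4 values shown sits.

From the compounds shown here alone, the actual dose needed for compound 4 remains open. So does whether an unsubstituted phenyl, 4-methoxyphenyl or 4-trifluoromethylphenyl on the same ring nitrogen would give a similar result.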